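The source may hold more compounds than are shown below. What is called first, only, known or untested is meant among the compounds shown, and "the series" means these compounds.

Values in a functional assay on HCT-116 cells (Homo sapiens) for antiproliferative activity, read by MTT assay, with a stated time of 48 h; on this read-out lower numbers stand for stronger inhibition and higher numbers for weaker inhibition:
Compound 1 `CCCCCCC(CCO)n1cnc2c(Cl)ncnc21`: 11900 nM
Compound 2 `CCCCCCC(CCO)n1cnc2c(OC)ncnc21`: > 50000 nM (a limit)
Compound 3 `CCCCCCC(CCO)n1cnc2cncnc21`: > 50000 nM (a limit)

Compound 2 stands on a limit of the assay, not on a number: > 50000 nM. This is the limit of > 50000 nM in this assay, at which 2 of the 3 values shown sit. Compound 4 `CCCCCCCCCCC(CCO)n1cnc2c(OC)ncnc21` is compound 2 with one change: butyl in place of hydrogen on a saturated chain carbon, seven bonds along the chain from an aromatic nitrogen.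

The measured steps all concern the group on the aromatic carbon of the shared core, not the chain. Going by the values given here, two of them start from the only true number: an at least 4.2-fold higher number from compound 1 to compound 2 (0.62 log units; beyond the scatter) and an at least 4.2-fold higher number from compound 1 to compound 3 (0.62 log units; beyond the scatter). The third is a step that the two limits leave unreadable from compound 2 to compound 3. None of them gives a size for the butyl change, so the expectation rests on weak ground.

Compound 4 keeps the methoxy group of compound 2, and the step of an at least 4.2-fold higher number from compound 1 to compound 2 (0.62 log units; beyond the scatter) shows that this group goes with weak inhibition in this assay. A large gain is therefore not expected, and only a small move toward lower numbers seems reasonable. The assay may well report only a limit again. The expected step, which is an estimate and may not prove readable, is an at least 1.2-fold lower number from compound 2 to compound 4 (0.09 log units; that floor lies within the scatter). For compound 4 the estimated value is 40000 nM, with an expected range from 15000 nM to 80000 nM.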

Compound 4, half-maximal inhibitory concentration: 7530 nM
Compound 4: the middle estimate sits 5.3-fold (0.73 log units) above what was measured; the whole stated range lies above it.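

In this assay, going by these compounds alone, the earlier compounds differed only on an aromatic carbon of the shared core, so they said nothing about the chain; the butyl placed on a saturated chain carbon, seven bonds along the chain from an aromatic nitrogen, now gives an at least 6.6-fold lower number from compound 2 to compound 4 (0.82 log units; beyond the scatter) as a step of its own. The methoxy group therefore does not by itself keep a compound at weak inhibition, since this single chain change brings compound 4 to 7530 nM with the methoxy group kept in place. The size of the step is only a floor and the real difference may be larger, because compound 2 stands on a limit and not on a number: the limit of > 50000 nM in this assay, at which 2 of the 4 values shown sit.

As far as these compounds go, what a still longer chain would do at this place remains open, as does whether an amine in place of the butyl would give a step of similar size. Also open is whether the same butyl change would move the number as far with chloro or hydrogen on the aromatic carbon; the compounds shown pair it only with the methoxy group.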